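This account rests on a few compounds, and the source may have more. Where it says the series, first, only, none or still open, it means among the compounds named here.

Measured so far:
- compound 1, `COC(=O)C1=C(C)N(c2ccc(OC)cc2)C=C(C)C1c1ccccc1`, with -28.9%
- compound 2, `COC(=O)C1=C(C)N(c2ccccc2)C=C(C)C1c1ccccc1`, with -37.4%
- compound 3, `COC(=O)C1=C(C)N(c2cccc(Cl)c2)C=C(C)C1c1ccccc1`, with -22.8%

These three compounds share one core and differ only in the group carried on the ring nitrogen. In a functional assay for inhibition, using microsomes, tested at 200 ug/mL (on this read-out lower numbers stand for a stronger effect and higher numbers for a weaker effect at the one concentration tested), compound 3 holds the highest of the three numbers; its nearest neighbour is compound 1, a step of a number 6.1 percentage points higher from compound 1 to compound 3 (within the scatter), and its furthest is compound 2, a step of a number 14.6 percentage points higher from compound 2 to compound 3 (beyond the scatter). The first of these steps is within the scatter, the second a modest change beyond it.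

Compound 4, `COC(=O)C1=C(C)N(c2cccc(C)c2C)C=C(C)C1c1ccccc1`, differs from compound 3 by 2,3-dimethylphenyl in place of 3-chlorophenyl on an amine nitrogen in a ring. Both measured steps that end at compound 3 bear on this change, since they also swap the aryl group on that nitrogen; one was within the scatter, the other modest. A change of similar or smaller size is therefore expected here, with no clear direction, so the expected step in this assay is a number 2.2 percentage points lower from compound 3 to compound 4 (within the scatter). Compound 4 is estimated at -25%, within a range from -42% to -8%.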

Compound 4, a percentage reported as activity, at one concentration (the size of the read-out at that concentration, not a potency): -33.1%
Compound 4: the middle estimate sits 8.1 percentage points above what was measured; low and high end bracket the measured number.
By their numbers in this assay, from the lowest: compounds 2, 4, 1 and 3 (each within the scatter of the next, the first and the last beyond it).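

In this assay, the step of a number 10.3 percentage points lower from compound 3 to compound 4 (beyond the scatter) shows that replacing 3-chlorophenyl with 2,3-dimethylphenyl on the ring nitrogen can move the number beyond the scatter, though only modestly. The other two steps, a number 4.3 percentage points higher from compound 2 to compound 4 (within the scatter) and a number 4.2 percentage points lower from compound 1 to compound 4 (within the scatter), show that an aryl group with two methyl groups stays within the scatter of both plain phenyl and 4-methoxyphenyl, so compound 3 now differs beyond the scatter from two of the other three compounds, with compound 1 the exception. Nothing measured here explains why these steps differ in size.

From the compounds shown here alone, all four compounds carry an aryl group on this nitrogen, so it remains open how a benzyl group, a cyclohexyl group or a phenyl ring bearing an amine or a carboxylic acid would behave. The methoxycarbonyl and phenyl groups on the shared core also stay the same throughout, leaving the effect of changing them unknown.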